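Swapping the Amino Group on a Shared Core

The source may report more compounds than this note shows. Statements on the series, on what has been measured and on what is new or still open speak of the compounds shown alone.

Three compounds built on one shared core have been examined in an ADME assay on A549 cells (Homo sapiens) for cytotoxicity, read by resazurin assay, with a stated time of 48 h (on this read-out lower numbers stand for higher toxicity in this test and higher numbers for lower toxicity in this test), so far. There, compound 1 (`CC(=O)Nc1ccc(NC(=O)c2cc(Cl)ccc2O)c(Cl)c1`) is recorded as "not determined" (no result reported) and so offers no number to compare. Compound 2 (`CCCCCCCCC(C)Nc1ccc(NC(=O)c2cc(Cl)ccc2O)c(Cl)c1`) gives 21900 nM as its reading, and compound 3 (`O=C(Nc1ccc(NCC2CCCC2)cc1Cl)c1cc(Cl)ccc1O`) gives 21500 nM as its reading. Within the data shown here, these are the only two numbers available, and they lie within the scatter of each other, so compound 3 stands level with compound 2.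

The next compound to be tested is compound 4 (`CCCN(CCC)c1ccc(NC(=O)c2cc(Cl)ccc2O)c(Cl)c1`), which has dipropylamino in place of (cyclopentylmethyl)amino on an aromatic carbon is the full count of that change. Among the measured compounds shown here, no pair of measured compounds differs in one place only, so there is no direct precedent for the size of this step. For the measured compounds named here, the only guide is that compound 2 at 21900 nM and compound 3 at 21500 nM carry different groups at this carbon yet do not separate in this assay at all. No step beyond the scatter is therefore expected, in either direction, and the estimated change is a 1.2-fold higher number from compound 3 to compound 4 (0.07 log units; within the scatter) and no more. For compound 4 the expected value is 25000 nM within an estimated range of 11000 nM to 55000 nM in this test.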

Compound 4, half-maximal cytotoxic concentration: 10700 nM
Compound 4: the middle estimate sits 2.3-fold (0.37 log units) above what was measured, and the stated range ends above it.
By their numbers in this assay, from the lowest: compounds 4, 3 and 2 (each within the scatter of the next, the first and the last beyond it).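

In this assay, among these compounds, dipropylamino in place of (cyclopentylmethyl)amino gives a 2.0-fold lower number from compound 3 to compound 4 (0.30 log units; within the scatter), the first step at this aromatic carbon that can be read from a single change. The entering group has no hydrogen-bond donor and no ring, while the leaving group has both, and the heavy-atom count stays the same, so this position has now taken an amino group that lacks both features without a step beyond the scatter. The step lies at the edge of that scatter and rests on a single pair, and nothing shown accounts for its size or direction.

The compounds shown leave open whether a ring that carries the nitrogen itself, as in morpholine or piperidine, would read differently from the open dipropylamino chains at this carbon. They also leave open what a shorter dimethylamino group or a chain ending in a carboxylic acid would do here, and compound 1 offers no number against which to judge its acetylamino group.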